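This account rests on a few compounds, and the source may have more. Where it says the series, first, only, none or still open, it means among the compounds named here.

The series rests on the core of compound 1 `CC1CCN(C2CCN(S(=O)(=O)c3cccc(Br)c3)CC2)CC1`, with compound 2 `COc1ccccc1-c1cccc(S(=O)(=O)N2CCC(N3CCC(C)CC3)CC2)c1` and compound 3 `CC1CCN(C2CCN(S(=O)(=O)c3cccnc3F)CC2)CC1` as its measured relatives and compound 4 `COc1cccc(S(=O)(=O)N2CCC(N3CCC(C)CC3)CC2)c1` still to be measured. In an ADME assay on HCT-116 cells (Homo sapiens) for cytotoxicity, read by CellTiter-Glo, with a stated time of 72 h (a higher number here means a weaker inhibitor, a lower number a stronger inhibitor), compound 1 returns only a limit, > 5000 nM. In this assay compound 2 likewise returns only a limit, > 5000 nM. Compound 3 also stands at a limit, > 10000 nM in this assay, so no measured number places it among the three. The two measured steps, a step that the two limits leave unreadable from compound 1 to compound 2 and a step that the two limits leave unreadable from compound 1 to compound 3, are both unreadable in size; the limit of > 10000 nM in this assay, at which 1 of the 3 values shown sits, and the limit of > 5000 nM in this assay, at which 2 of the 3 values shown sit, are all the evidence there is. The change to compound 4 is 3-methoxyphenyl in place of 2-fluoropyridin-3-yl on a sulfonyl sulfur. For the measured compounds named here, with none of the measured steps readable, no step beyond the scatter can be foreseen in this assay in either direction, and a further limit is the likeliest outcome. Compound 4 is therefore expected to give 10000 nM, with a range from 4000 nM to 50000 nM. The step of a number no higher from compound 3 to compound 4 (the limit leaves the size open) that this estimate implies is expected to be no more than scatter.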

Compound 4, half-maximal inhibitory concentration: > 5000 nM
Compound 4 was reported as a limit (the forecaster's own chance of this, stated with the estimate: 85%); the middle value is on the limit's open side.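

In this assay compound 4 gives > 5000 nM, which is a limit. Its steps from compound 1, compound 2 and compound 3 therefore cannot be read. The compounds shown leave open whether any change to the shared core yields a measurable half-maximal inhibitory concentration.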